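This account rests on a few compounds, and the source may have more. Where it says the series, first, only, none or still open, it means among the compounds named here.

Compound 1 `CS(=O)(=O)c1ccc(CSc2nc(-c3ccc(F)cc3)c(-c3ccncc3)[nH]2)cc1`: 330 nM
Compound 2 `CS(=O)(=O)c1ccc(CSc2nc(-c3ccc(Cl)cc3)c(-c3ccncc3)[nH]2)cc1`: 320 nM
Compound 3 `CS(=O)(=O)c1ccc(CSc2nc(-c3ccccc3)c(-c3ccncc3)[nH]2)cc1`: 1700 nM

In a functional assay (Homo sapiens) for inhibition (on this read-out lower numbers stand for stronger inhibition and higher numbers for weaker inhibition), compound 1 stands level with compound 2, with a 1.0-fold lower number from compound 1 to compound 2 (0.01 log units; within the scatter). Together they hold the lower end of the three numbers. Replacing the halogen with hydrogen on an aromatic carbon gives a 5.2-fold higher number from compound 1 to compound 3 (0.71 log units; beyond the scatter), and likewise a 5.3-fold higher number from compound 2 to compound 3 (0.73 log units; beyond the scatter).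

Compound 4 `Oc1ccccc1CSc1nc(-c2ccc(F)cc2)c(-c2ccncc2)[nH]1`, not yet measured, is changed elsewhere: 2-hydroxyphenyl in place of 4-(methylsulfonyl)phenyl on a saturated chain carbon bound to a sulfur. In words, 2-hydroxyphenyl stands in place of 4-(methylsulfonyl)phenyl on a saturated chain carbon bound to a sulfur. For the measured compounds named here, none of the measured steps touches this place, so they give no direction for the change. Going by the values given here, they show only that one change in these compounds can move the number clearly, as with a 5.2-fold higher number from compound 1 to compound 3 (0.71 log units; beyond the scatter). The best guess therefore stays close to compound 1, with a wide margin on both sides. The expected result is a 1.2-fold higher number from compound 1 to compound 4 (0.08 log units; within the scatter), which is no clear step in either direction. For compound 4 the estimated value is 400 nM, with an expected range from 80 nM to 2000 nM.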

Compound 4, half-maximal inhibitory concentration: 440 nM
For compound 4 the middle estimate is 1.1-fold (0.04 log units) below the measured one; measured number inside the range.
By their numbers in this assay, from the lowest: compounds 2, 1 and 4 (each within the scatter of the next); then compound 3.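

In this assay, moving to the new group gives a 1.3-fold higher number from compound 1 to compound 4 (0.12 log units; within the scatter) and so no clear shift in the number. For the compounds shown here, this is the first sign that this position, on a saturated chain carbon bound to a sulfur, accepts 2-hydroxyphenyl in place of 4-(methylsulfonyl)phenyl, even though the entering group has fewer heavy atoms and brings a hydrogen-bond donor. Among these compounds, then, the methylsulfonyl group is not needed for a number in this range, and nothing available explains why the two groups read alike.

Still open, on these data alone, is whether a plain phenyl, a phenyl carrying an amine or a carboxylic acid, or a longer chain at this place would read the same. As far as these compounds go, it is also open whether 2-hydroxyphenyl would behave the same way with the chloro group of compound 2.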